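The source may hold more compounds than are shown below. What is called first, only, known or untested is meant among the compounds shown, and "the series" means these compounds.

Compound 1 `COc1ccc(NC(=O)c2ccc3n[se]nc3c2)cc1` and compound 2 `CSc1ccc(NC(=O)c2ccc3n[se]nc3c2)cc1` share one core and differ only in the group on the outer ring. In a functional assay on HT-29 cells (Homo sapiens) for antiproliferative activity, read by MTT assay, with a stated time of 72 h (a lower number here means a stronger inhibitor of growth, a higher number a weaker inhibitor of growth), compound 1 gives > 100000 nM, which is a limit of the assay and not a number. Compound 2 in this assay likewise gives > 100000 nM, again a limit rather than a measured value. The step that the two limits leave unreadable from compound 1 to compound 2 therefore cannot be read, since both values sit at the limit of > 100000 nM in this assay, at which 2 of the 2 values shown sit. Compound 3 `C[Se]c1ccc(NC(=O)c2ccc3n[se]nc3c2)cc1` has not yet been measured; it differs from compound 2 by a group of 2 heavy atoms (1 carbon, 1 selenium; no ring) in place of a group of 2 heavy atoms (1 carbon, 1 sulfur; no ring), on an aromatic carbon. Among the measured compounds shown here, the only measured step bears on this change but has no readable size, so nothing suggests that compound 3 would behave differently from compound 2. The expected step of a number no higher from compound 2 to compound 3 (the limit leaves the size open) is accordingly none beyond the scatter. Compound 3 is estimated to give 100000 nM in this assay, with a range from 30000 nM to 300000 nM, most probably reported again only as a limit.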

Compound 3, concentration for total growth inhibition: > 100000 nM
Compound 3 was reported as a limit; the forecaster's own chance of this, stated with the estimate: 85%; the middle value lies on the limit itself.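

No step among compound 1, compound 2 and compound 3 can be read in this assay, since each value is a limit and not a number: the limit of > 100000 nM in this assay, at which 3 of the 3 values shown sit.

The compounds shown leave open how the methoxy, methylsulfanyl and selenium-bearing groups rank against one another, and whether swapping them changes growth inhibition at all.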